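Stilbene sulfonamides: hydroxy for fluoro on the distal ring

A few compounds are considered here, and "the series" means these few. Any claim that something is new, unique, unknown or untested is made for them only; others in the source may bear on it.

Measured compounds:
- compound 1, `COc1cccc(/C=C/c2ccc(S(N)(=O)=O)cc2)c1`: 21000 nM
- compound 2, `NS(=O)(=O)c1ccc(/C=C/c2ccc(F)cc2)cc1`: 45100 nM

In a functional assay on NCI-H23 cells (Homo sapiens) for inhibition (on this read-out higher numbers stand for weaker inhibition of growth and lower numbers for stronger inhibition of growth), compound 1 gives 21000 nM. In this assay compound 2 gives 45100 nM, the highest of the two numbers in hand; compound 1 lies below it by a margin that is beyond the usual scatter, so compound 2 is the weaker of the two growth inhibitors measured so far. Within the data shown here, no step between compounds differing in one place is available, so the two values can only be set side by side.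

Compound 3, `NS(=O)(=O)c1ccc(/C=C/c2ccc(O)cc2)cc1`, remains to be measured. Its change from compound 2 is hydroxy in place of fluoro on an aromatic carbon. With nothing in the measured pair that isolates the effect of a hydroxy group on this ring, the step from compound 2 to compound 3 is expected to be small, in either direction, and most likely within the scatter, with a slight lean toward a lower number; the expected step is a 1.5-fold lower number from compound 2 to compound 3 (0.18 log units; within the scatter). Compound 3 is accordingly estimated at 30000 nM in this assay, within the range 9000 nM to 90000 nM.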

Compound 3, concentration for 50% growth inhibition: 16900 nM
Compound 3: middle estimate off by 1.8-fold (0.25 log units), on the high side, within the range that was stated.
By their numbers in this assay, from the lowest: compounds 3 and 1 (each within the scatter of the next); then compound 2.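

In this assay, the series gains its first comparison that differs in one place: hydroxy in place of fluoro on an aromatic carbon, para to a large group, gives a 2.7-fold lower number from compound 2 to compound 3 (0.43 log units; beyond the scatter). This aromatic carbon therefore responds to the exchange of one heavy atom, and the change goes toward stronger inhibition of growth, though the step remains modest. By the counts, hydroxy brings a hydrogen-bond donor and a hydrogen-bond acceptor that fluoro lacks, but a single pair cannot separate these from any other difference between the two groups, and no supporting measurement is available to explain the step.

Going by these compounds, whether an amine or a carboxylic acid on the same aromatic carbon would match hydroxy, or would fall back toward fluoro, remains open, as does the outcome for a hydrogen atom there. Compound 1 differs from compound 3 in more than one place, so it cannot show whether methoxy at this position would retain the lower number seen with hydroxy.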